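A few compounds are considered here, and "the series" means these few. Any claim that something is new, unique, unknown or untested is made for them only; others in the source may bear on it.

Three compounds of one series have been measured in an ADME assay on the whole organism for cytotoxicity, with Artemia salina as the target, with a stated time of 24 h; a lower number here means that less compound is needed, a higher number that more compound is needed for the effect:

compound 1 `COc1ccc(/C=C/C(=O)c2ccccc2NC(=O)NS(=O)(=O)c2ccc(C)cc2)cc1` gives 28.1 ug/mL;
compound 2 `Cc1ccc(S(=O)(=O)NC(=O)Nc2ccccc2C(=O)/C=C/c2cccc(O)c2)cc1` gives 39.3 ug/mL;
compound 3 `Cc1ccc(S(=O)(=O)NC(=O)Nc2ccccc2C(=O)/C=C/c2ccccc2Cl)cc1` gives 12.8 ug/mL.

Compound 1 stands second highest of the three numbers: the step of a 1.4-fold higher number from compound 1 to compound 2 (0.15 log units; within the scatter) lies within the scatter, while the step of a 2.2-fold lower number from compound 1 to compound 3 (0.34 log units; beyond the scatter) is a modest one beyond it. Compound 4 `Cc1ccc(S(=O)(=O)NC(=O)Nc2ccccc2C(=O)/C=C/c2ccncc2)cc1` has not yet been measured in this assay. It differs from compound 1 in one place: pyridin-4-yl in place of 4-methoxyphenyl on a double-bonded chain carbon bound to a double-bonded chain carbon. Among the compounds with values here, no measured step brings pyridin-4-yl onto a double-bonded chain carbon bound to a double-bonded chain carbon, so nothing bears on this change directly. The two steps that alter the same group, a 1.4-fold higher number from compound 1 to compound 2 (0.15 log units; within the scatter) and a 2.2-fold lower number from compound 1 to compound 3 (0.34 log units; beyond the scatter), show that replacing one ring there has moved the number by no more than a modest amount, and the step of a 3.1-fold lower number from compound 2 to compound 3 (0.49 log units; beyond the scatter) spans the whole range seen so far. A change of at most that size is therefore expected for compound 4, with no direction that can be called beyond the scatter. The estimate for compound 4 in this assay is 30 ug/mL, with a range from 12 ug/mL to 75 ug/mL. This estimate means an expected step of a 1.1-fold higher number from compound 1 to compound 4 (0.03 log units; within the scatter).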

Compound 4, concentration for half-maximal effect: 16.8 ug/mL
Compound 4: the middle estimate sits 1.8-fold (0.25 log units) above what was measured; the measured number falls inside the stated range.
By their numbers in this assay, from the lowest: compounds 3, 4, 1 and 2 (each within the scatter of the next, the first and the last beyond it).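

In this assay, within the data shown here, pyridin-4-yl is the first ring with a hetero atom seen on a double-bonded chain carbon bound to a double-bonded chain carbon, and replacing 4-methoxyphenyl with it gives only a small step (a 1.7-fold lower number from compound 1 to compound 4 (0.22 log units; within the scatter)). The same holds against 2-chlorophenyl (a 1.3-fold higher number from compound 3 to compound 4 (0.12 log units; within the scatter)), while the gap to 3-hydroxyphenyl is modest (a 2.3-fold lower number from compound 2 to compound 4 (0.37 log units; beyond the scatter)). The hetero ring thus stays inside the span of the carbon-only rings, and nothing shown gives a reason for this.

The compounds shown leave open whether pyridin-3-yl or pyridin-2-yl would behave like pyridin-4-yl. They also leave open whether a ring is needed at this place at all, which a carboxylic acid or an amine there would address.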